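Adding an isopropoxy group to compound 3

This account rests on a few compounds, and the source may have more. Where it says the series, first, only, none or still open, it means among the compounds named here.

Measured in an ADME assay on HEK293 cells (Homo sapiens) for cytotoxicity, read by MTT assay, with a stated time of 72 h; on this read-out higher numbers stand for weaker inhibition and lower numbers for stronger inhibition:
- Compound 1 `COc1ccc(C2=C(c3cc(OC)c(OC)c(OC)c3)C(=O)C(OC(C)=O)C2)cc1OC(C)C` gives > 100 ug/mL (a limit)
- Compound 2 `COc1ccc(C2=C(c3cc(OC)c(OC)c(OC)c3)C(=O)C(O)C2)cc1` gives 6.3 ug/mL
- Compound 3 `COc1ccc(C2=C(c3cc(OC)c(OC)c(OC)c3)C(=O)C(O[SiH2]C(C)(C)C)C2)cc1` gives > 100 ug/mL (a limit)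

Compound 3 gives > 100 ug/mL, which is a limit and not a number. It stands with one other compound at the limit of > 100 ug/mL in this assay, at which 2 of the 3 values shown sit.

Compound 4 `COc1ccc(C2=C(c3cc(OC)c(OC)c(OC)c3)C(=O)C(O[SiH2]C(C)(C)C)C2)cc1OC(C)C` differs from compound 3 in one place: isopropoxy in place of hydrogen on an aromatic carbon. In words, this is isopropoxy in place of hydrogen on an aromatic carbon, turning 4-methoxyphenyl into 3-isopropoxy-4-methoxyphenyl.

Among the measured compounds shown here, the only measured step is an at least 15-fold higher number from compound 2 to compound 3 (1.20 log units; beyond the scatter), a large one, but it lies at a different place in the structure. Compound 1 already carries the isopropoxy group and gives > 100 ug/mL, also a limit. For the measured compounds named here, no pair of compounds measures this change directly, so no step beyond the scatter is expected in this assay, and a further limit is the likeliest report. The step expected is a number no higher from compound 3 to compound 4 (the limit leaves the size open). Compound 4 is expected near 100 ug/mL, with an estimated range from 40 ug/mL to 250 ug/mL.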

Compound 4, half-maximal inhibitory concentration: > 100 ug/mL
Compound 4: no number, only a limit (the forecaster's own chance of this, stated with the estimate: 80%); the middle value sits exactly at the limit.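

Compound 4 reports only a limit in this assay, as do compound 1 and compound 3, so neither step to compound 4 can be read: the limit of > 100 ug/mL in this assay, at which 3 of the 4 values shown sit.

The compounds shown leave open whether isopropoxy in place of hydrogen changes the read-out at all.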